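Anilide series, D4 efficacy: estimate for compound 4

The source may report more compounds than this note shows. Statements on the series, on what has been measured and on what is new or still open speak of the compounds shown alone.

Measured compounds:
compound 1, `CCc1cccc(NC(=O)CN2CCC(c3cccc[n+]3[O-])CC2)c1`, 62%
compound 2, `O=C(CN1CCC(c2cccc[n+]2[O-])CC1)Nc1cccc(-c2ccccc2)c1`, 75%
compound 3, `CSc1cccc(NC(=O)CN2CCC(c3cccc[n+]3[O-])CC2)c1`, 56%

Three anilides on the shared core have been run in a functional assay on HEK293 cells for agonist activity at D(4) dopamine receptor (Homo sapiens), read by FLIPR; a lower number here means a smaller maximal response, a higher number a larger maximal response. Compound 2 gives 75%, compound 1 gives 62%, and compound 3 gives 56%. Compound 3 holds the lowest of the three numbers; its nearest neighbour is compound 1, with a number 6 percentage points lower from compound 1 to compound 3 (within the scatter), and the furthest is compound 2, with a number 19 percentage points lower from compound 2 to compound 3 (beyond the scatter). Only the swap to phenyl moved the read-out beyond the scatter, as a number 13 percentage points higher from compound 1 to compound 2 (beyond the scatter) also shows.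

Compound 4, `O=C(CN1CCC(c2cccc[n+]2[O-])CC1)Nc1cccc(OC(F)(F)F)c1`, is the next member. The change from compound 3 is trifluoromethoxy in place of methylsulfanyl on an aromatic carbon. Within the data shown here, the steps that bear on it are the two that replace the methylsulfanyl group: the exchange with ethyl stayed within the scatter, the exchange with phenyl did not. Trifluoromethoxy carries more heavy atoms than ethyl or methylsulfanyl but no ring, so the comparison is imperfect. On that basis compound 4 is expected to sit close to compound 3, and the estimated step is a number 4 percentage points higher from compound 3 to compound 4 (within the scatter). The expected value for compound 4 is 60%, within a range from 45% to 75%.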

Compound 4, largest response reached (reported as efficacy), in percent of the reference or control that the assay uses: 51%
For compound 4 the middle estimate is 9 percentage points above the measured one; low and high end bracket the measured number.
By their numbers in this assay, from the lowest: compounds 4, 3 and 1 (each within the scatter of the next, the first and the last beyond it); then compound 2.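

In this assay, among these compounds, trifluoromethoxy is the first group without a ring to separate from ethyl on this aromatic carbon, with a number 11 percentage points lower from compound 1 to compound 4 (beyond the scatter) as the step, whereas the exchange of ethyl for methylsulfanyl stayed within the scatter. Against methylsulfanyl the same group gives a number 5 percentage points lower from compound 3 to compound 4 (within the scatter) and the two cannot be ranked, although trifluoromethoxy brings 5 heavy atoms where methylsulfanyl has 2, so a higher heavy-atom count alone does not raise the read-out across this pair. Among the compounds shown here, compound 2 stays apart from the other three, and a number 24 percentage points lower from compound 2 to compound 4 (beyond the scatter) is the widest step in the set, which leaves phenyl as the only group here that goes with a larger maximal response.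

On these data alone, whether the ring itself goes with the higher number remains open, and a cyclopropyl or pyridyl group, a longer chain such as butyl, or an amine or a carboxylic acid on this aromatic carbon would help to settle that. Nothing on hand accounts for any of these differences.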